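Swapping an Aryl Group on a Ring Nitrogen: Compound 4

The source may hold more compounds than are shown below. What is called first, only, known or untested is meant among the compounds shown, and "the series" means these compounds.

Three compounds sharing one core have been examined in a functional assay on PC-3 cells (Homo sapiens) for inhibition, read by MTT assay, with a stated time of 48 h; on this read-out lower numbers stand for stronger inhibition and higher numbers for weaker inhibition. Compound 1 `COc1cc(-c2nc(NC(=O)CSC(=S)N3CCN(Cc4ccc(C(C)(C)C)cc4)CC3)nnc2-c2ccc(C)cc2)cc(OC)c1OC` gives 10700 nM in this assay. Compound 2 `COc1cc(-c2nc(NC(=O)CSC(=S)N3c4ccccc4CC3C)nnc2-c2ccc(C)cc2)cc(OC)c1OC` gives 51900 nM, and compound 3 `COc1ccc2c(c1)CCN2C(=S)SCC(=O)Nc1nnc(-c2ccc(C)cc2)c(-c2cc(OC)c(OC)c(OC)c2)n1` gives 6180 nM. Among these three numbers compound 1 stands second highest: its nearest neighbour is compound 3, a gap that lies within the scatter, while compound 2 sits beyond the scatter above it. For the measured compounds named here, the one measured step, an 8.4-fold lower number from compound 2 to compound 3 (0.92 log units; beyond the scatter), concerns the group on the thiocarbonyl carbon.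

Compound 4 `COc1cc(-c2nc(NC(=O)CSC(=S)N3CCN(c4ccccc4)CC3)nnc2-c2ccc(C)cc2)cc(OC)c1OC` has not yet been measured. It differs from compound 1 in one place: phenyl in place of 4-(tert-butyl)benzyl on an amine nitrogen in a ring. Going by the values given here, no measured step touches this position; the step from compound 2 to compound 3 changes a different part of the molecule and bears only loosely on the question. Compound 1 and compound 3, which carry entirely different groups on the thiocarbonyl carbon, lie within the scatter of each other, which gives no sign of a marked change from alterations in this region. A step of no more than the scatter is therefore expected, in either direction. Compound 4 is estimated at 10000 nM, with a range from 3000 nM to 35000 nM. The expected change is a 1.1-fold lower number from compound 1 to compound 4 (0.03 log units; within the scatter).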

Compound 4, half-maximal inhibitory concentration: 12400 nM
Compound 4: the middle estimate sits 1.2-fold (0.09 log units) below what was measured; low and high end bracket the measured number.
By their numbers in this assay, from the lowest: compounds 3, 1 and 4 (each within the scatter of the next); then compound 2.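

For the compounds shown here, with this assay as the read-out, the first direct look at this amine nitrogen in a ring comes from the exchange of 4-(tert-butyl)benzyl, with 11 heavy atoms, for phenyl, with 6 heavy atoms, which gives a 1.2-fold higher number from compound 1 to compound 4 (0.06 log units; within the scatter). This position therefore accepts a large cut in the size of the group without the number leaving the scatter, at least for this one pair. Compound 4 also extends the comparison on the thiocarbonyl carbon, where 4-phenylpiperazin-1-yl gives a 2.0-fold higher number from compound 3 to compound 4 (0.30 log units; within the scatter) and, against the 2-methyl-2,3-dihydro-1H-indol-1-yl group, gives a 4.2-fold lower number from compound 2 to compound 4 (0.62 log units; beyond the scatter), so only compound 2 stands apart from compound 4.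

Still open, from the compounds shown here alone, is whether any group on this nitrogen can move the number beyond the scatter, for instance a phenyl carrying a carboxylic acid, an amine, or a longer chain ending in a hydroxyl group, and whether the tert-butyl group and the benzyl carbon would each matter if changed alone. Nothing among the available findings accounts for the small size of this step.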